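The compounds below may be only part of what the source reports. "The series", "measured", "known", "first", "only" and "open" are said of these compounds alone.

Measured compounds in the series:

- compound 1, `O=C1N(Cc2ccc(Cl)cc2)CCC12CCN(Cc1ccc(F)cc1)CC2`; in a functional assay on cells for antagonist activity at Voltage-dependent T-type calcium channel subunit alpha-1H (Homo sapiens), read by patch clamp, tested at 3 uM (a higher number here means more inhibition at the concentration tested (going by the name of the read-out), a lower number less inhibition), compound 1 gives 65%
- compound 2, `O=C1N(Cc2ccc(Cl)cc2)CCC12CCN(S(=O)(=O)c1ccc(F)cc1)CC2`; in this assay compound 2 gives 45%
- compound 3, `CC(C)N1CCC2(CCN(C(c3ccc(F)cc3)c3ccc(F)cc3)CC2)C1=O`; in this assay compound 3 gives 57%

Compound 3 stands second highest of the three numbers in this assay. Its nearest neighbour is compound 1, whose number is higher but within the usual scatter, so the two cannot be ranked against each other. Compound 2 lies lower, and that gap is beyond the scatter. Going by the values given here, no pair of measured compounds differs in a single place, so the series holds no measured step of that kind to lean on.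

Compound 4, `O=C1NCCC12CCN(C(c1ccc(F)cc1)c1ccc(F)cc1)CC2`, differs from compound 3 as follows: hydrogen in place of isopropyl on an amide-type nitrogen in a ring. From the compounds shown here alone, every measured compound carries a group on that amide-type nitrogen; none has the bare amide hydrogen there, so this change is untested. The expectation is a moderate fall in inhibition, a number 12 percentage points lower from compound 3 to compound 4 (beyond the scatter), in this assay, with wide uncertainty. Compound 4 is estimated to give 45% in this assay, with a range from 25% to 65%.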

Compound 4, a percentage reported as inhibition, at one concentration (the size of the read-out at that concentration, not a potency): < 20%
Compound 4 was reported as a limit; the forecaster's own chance of this, stated with the estimate: 5%; at least 25 percentage points between middle value and limit.
By their numbers in this assay, from the lowest: compound 2; then compounds 3 and 1 (each within the scatter of the next). At a limit, below all of these: compound 4.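

In this assay, hydrogen in place of isopropyl on the amide-type nitrogen in the ring gives a number at least 37 percentage points lower from compound 3 to compound 4 (beyond the scatter). Going by these compounds alone, every earlier compound carried a group on that nitrogen, so this is the first sign that the position is sensitive to what it bears: with the rest of compound 3 unchanged, the bare amide hydrogen leaves little of the inhibition seen at the concentration tested. The true size of the step remains unfixed, as compound 4 stands at a limit of the assay rather than at a number: the limit of < 20% in this assay, at which 1 of the 4 values shown sits.

From the compounds shown here alone, whether a small group such as methyl on that nitrogen, or a longer chain such as n-butyl, would keep the inhibition of compound 3 remains open, and with it whether any group will do or isopropyl matters in particular. Also open, going by these compounds, is whether the bare amide hydrogen would bring a similar fall to compound 1, which carries a different group on its other ring nitrogen.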